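The source may hold more compounds than are shown below. What is called first, only, known or untested is meant among the compounds shown, and "the series" means these compounds.

Compound 1 `COc1cc2ncnc(Nc3cccc(C(=O)O)c3)c2cc1OC` is the anchor of this small set. In an assay on isolated protein for inhibition of vascular endothelial growth factor receptor 1 (Homo sapiens), read by ELISA, with a stated time of 20 min, tested at 1 uM (a lower number here means less inhibition, a higher number more inhibition at the concentration tested (going by the name of the read-out)), compound 1 gives 32%. Two further compounds were measured alongside it. Compound 3 `CC1(C)OB(c2ccc3ncnc(Nc4ccc(F)c(Cl)c4)c3c2)OC1(C)C` gives 8% in this assay, a number lower than that of compound 1 by a gap that lies beyond the usual scatter. Compound 2 `COCCOc1cc2ncnc(Nc3ccc(B(O)O)cc3)c2cc1OC` is reported in this assay as "not active" (no number reported), with no number attached. Compound 1 thus stands highest of the two numbers available, with compound 3 the nearest and compound 2 returning no figure at all.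

The step under consideration leads to compound 4 `COc1cc2ncnc(Nc3cccc(CO)c3)c2cc1OC`. It differs from compound 1 in one place: hydroxymethyl in place of carboxy on an aromatic carbon. Going by the values given here, no pair of measured compounds in this set differs at this same position, so the size of the step from compound 1 to compound 4 cannot be read from a measured pair. With only single-concentration readings near the low end of the scale, a modest downward step in this assay is expected, though a change that stays within the scatter would not be surprising. The expected step is a number 12 percentage points lower from compound 1 to compound 4 (beyond the scatter). Compound 4 is therefore estimated to give 20% in this assay, within a range from 0% to 45%.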

Compound 4, a percentage reported as inhibition, at one concentration (the size of the read-out at that concentration, not a potency): "not active" (no number reported)
Compound 4: no number reported; there is nothing to compare the estimate with.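

Going by these compounds alone, compound 4 carries no number, so no step from compound 1 to compound 4 can be read from these results. Nothing shown here bears on the reason for this outcome. The compounds shown leave open how far hydroxymethyl in place of carboxy changes the reading in this assay for compound 4.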